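The source may hold more compounds than are shown below. What is called first, only, known or untested is meant among the compounds shown, and "the series" means these compounds.

- Compound 1 `Cc1cccc(-c2nn(-c3ccccc3)cc2C(Nc2nc3ccccc3s2)c2c(O)ccc3ccccc23)c1`: 17300 nM
- Compound 2 `O=[N+]([O-])c1ccc(-c2nn(-c3ccccc3)cc2C(Nc2nc3ccccc3s2)c2c(O)ccc3ccccc23)cc1`: 14700 nM

Among the measured compounds shown here, in a functional assay on MCF7 cells (Homo sapiens) for antiproliferative activity, read by MTT assay, with a stated time of 48 h (on this read-out lower numbers stand for stronger inhibition and higher numbers for weaker inhibition), compound 2 stands level with compound 1, the only other compound measured. Compound 3 `Oc1ccc2ccccc2c1C(Nc1nc2ccccc2s1)c1cn(-c2ccccc2)nc1-c1cccc(Cl)c1` differs from compound 2 in one place, with 3-chlorophenyl in place of 4-nitrophenyl on an aromatic carbon. For the measured compounds named here, the one measured step at this carbon, a 1.2-fold lower number from compound 1 to compound 2 (0.07 log units; within the scatter), put 4-nitrophenyl in place of 3-methylphenyl, so no step beyond the scatter is expected here. The expected change is a 1.0-fold higher number from compound 2 to compound 3 (0.01 log units; within the scatter). Compound 3 is estimated at 15000 nM, with an expected range of 7500 nM to 30000 nM.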

Compound 3, half-maximal inhibitory concentration: 20700 nM
Estimate against measurement, compound 3: 1.4-fold (0.14 log units) below, within the range that was stated.
By their numbers in this assay, from the lowest: compounds 2, 1 and 3 (each within the scatter of the next).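

In this assay, a third substituted phenyl group at this aromatic carbon gives a 1.4-fold higher number from compound 2 to compound 3 (0.15 log units; within the scatter) and a 1.2-fold higher number from compound 1 to compound 3 (0.08 log units; within the scatter). Neither 3-chlorophenyl against 4-nitrophenyl nor chloro against methyl separates these compounds, so all three substituted phenyl groups sit level here. Nothing at hand gives a reason for these numbers. Open, from the compounds shown here alone, is whether a different kind of group on this carbon, such as an amine or a carboxylic acid, would give a step beyond the scatter.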